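The compounds below may be only part of what the source reports. "The series", "measured", "known", "first", "only" and "open" are said of these compounds alone.

Compound 2 `CC1(C)[C@H]2CC[C@]1(C)N(Cc1cn(-c3ccc(C#N)cc3)nn1)C(=O)C2` is one of three measured members of a series built on a shared core. In a functional assay on LoVo cells (Homo sapiens) for inhibition, read by MTT assay, with a stated time of 24 h (a lower number here means a stronger inhibitor, a higher number a weaker inhibitor), compound 2 gives 90 nM, which at the digits reported stands level with compound 1 `CC1(C)[C@H]2CC[C@]1(C)N(Cc1cn(-c3cccc(F)c3)nn1)C(=O)C2`, for which this assay gives 90 nM; together they are the lowest two of the three numbers, and the step of no change at the digits printed from compound 1 to compound 2 (within the scatter) lies within the scatter. The highest number belongs to compound 3 `CC1(C)[C@H]2CC[C@]1(C)N(Cc1cn(-c3ccc(O)cc3)nn1)C(=O)C2`, which gives 410 nM, so that the step of a 4.6-fold higher number from compound 2 to compound 3 (0.66 log units; beyond the scatter) is the largest in the set, while a 4.6-fold higher number from compound 1 to compound 3 (0.66 log units; beyond the scatter) is of the same size.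

Compound 4 `CC1(C)[C@H]2CC[C@]1(C)N(Cc1cn(-c3cccc(O)c3)nn1)C(=O)C2` is not yet measured. It differs from compound 2 in one place: 3-hydroxyphenyl in place of 4-cyanophenyl on an aromatic nitrogen. Among the compounds with values here, the step from compound 2 to compound 3 bears most directly on it, since there too a hydroxy replaced a cyano on the aryl group and the number rose modestly; no measured pair isolates a 3-hydroxyphenyl against a 4-hydroxyphenyl, so the two cannot be told apart from these data. A modest rise of similar size is therefore expected, a 3.9-fold higher number from compound 2 to compound 4 (0.59 log units; beyond the scatter), and compound 4 is estimated at 350 nM, within a range of 120 nM to 1000 nM.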

Compound 4, half-maximal inhibitory concentration: 410 nM
Beside the measured number, compound 4's estimate is 1.2-fold (0.07 log units) below it, within the range that was stated.
By their numbers in this assay, from the lowest: compounds 1 and 2 (each within the scatter of the next); then compounds 3 and 4 (each within the scatter of the next).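

In this assay, within the data shown here, the exchange of 4-hydroxyphenyl for 3-hydroxyphenyl on the aromatic nitrogen gives no change at the digits printed from compound 3 to compound 4 (within the scatter) and so separates the two hydroxyphenyl groups for the first time: these numbers show no dependence on where the hydroxy stands. The rise seen with hydroxy therefore recurs with the 3-hydroxyphenyl group, which gives a 4.6-fold higher number from compound 2 to compound 4 (0.66 log units; beyond the scatter) when it replaces 4-cyanophenyl. The closest comparison sets the 3-hydroxyphenyl group against 3-fluorophenyl, with a 4.6-fold higher number from compound 1 to compound 4 (0.66 log units; beyond the scatter) showing that the rise also holds when the substituent's ring placement is kept.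

Nothing measured here bears on what lies behind this rise. From the compounds shown here alone, whether a methoxy or an amino group on the phenyl ring would give numbers like those of the hydroxy compounds or like those of compounds 1 and 2 stays open.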